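Swapping methoxy for bromo on a weak growth inhibitor

This account rests on a few compounds, and the source may have more. Where it says the series, first, only, none or still open, it means among the compounds named here.

Of the compounds shown here, three sharing one core have been tested so far in a functional assay on MDA-MB-231 cells (Homo sapiens) for inhibition, read by sulforhodamine B assay; a lower number here means a stronger inhibitor of growth, a higher number a weaker inhibitor of growth. Compound 1 `COc1ccc(CN2CCC=C(CCC(=O)NO)C2=O)cc1` gives 3860 nM, the highest number of the three, which makes it the weakest inhibitor of growth among them. Compound 3 `O=C(CCC1=CCCN(CCCCc2cccc3ccccc23)C1=O)NO` gives 1470 nM, and compound 2 `Cc1ccc(S(=O)(=O)Nc2ccc(CN3CCC=C(CCC(=O)NO)C3=O)cc2)cc1` gives 560 nM. Both numbers are clearly lower, but each of these compounds differs from compound 1 in more than one place, so neither shows what a single swap does.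

Compound 4 `O=C(CCC1=CCCN(Cc2ccc(Br)cc2)C1=O)NO` keeps the core of compound 1 and changes one group: bromo in place of methoxy on an aromatic carbon. This is bromo in place of methoxy on an aromatic carbon, para to a large group. Going by the values given here, no measured pair shows this kind of swap, so the expectation in this assay is only a small step towards a lower number, most likely within the scatter. The estimated step is a 1.5-fold lower number from compound 1 to compound 4 (0.19 log units; within the scatter). Compound 4 is expected at 2500 nM, with an estimated range of 1000 nM to 6000 nM.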

Compound 4, concentration for 50% growth inhibition: 1630 nM
The estimate for compound 4 lay 1.5-fold (0.19 log units) above the measured number; measured number inside the range.
By their numbers in this assay, from the lowest: compound 2; then compounds 3 and 4 (each within the scatter of the next); then compound 1.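

Going by these compounds alone, this is the first single change that can be read in this assay: with the rest of compound 1 kept, bromo in place of methoxy on an aromatic carbon, para to a large group, gives a 2.4-fold lower number from compound 1 to compound 4 (0.37 log units; beyond the scatter) and this modest step lies beyond the scatter. The group at this place therefore affects growth inhibition, and the methoxy group is not required for the activity seen in compound 1. The data offer no measured explanation for the size or direction of this step.

From the compounds shown here alone, it remains open whether other groups at the same place, such as chloro, an amine or a carboxylic acid, would shift the number further or reverse the step. It is also unclear whether the same swap would give a similar step on a compound with a longer chain between the core and the aromatic ring.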